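The compounds below may be only part of what the source reports. "The series", "measured", "known", "first", "only" and "open" are said of these compounds alone.

In a functional assay on CHO-K1 cells for agonist activity at Orexin/Hypocretin receptor type 1 (Homo sapiens), read by calcium flux (a lower number here means a smaller maximal response, a higher number a larger maximal response), compound 1 `COc1cccc(C(=O)NCCNc2cccc(NS(=O)(=O)c3cc(-c4cccc(C(=O)N(C)C)c4)ccc3OC)c2)c1` gives 49% as its largest response. Within the data shown here, this is the only number reported in the set: a second compound, compound 2 `COc1ccc(C(=O)NCCNc2cccc(NS(=O)(=O)c3cc(-c4cccc(C(=O)N(C)C)c4)ccc3OC)c2)cc1`, has "not determined" (no result reported) in this assay, so compound 1 stands alone and neither a higher nor a lower reference point is available from the measured material.

Compound 3 `COc1ccc(-c2cccc(C(=O)N(C)C)c2)cc1S(=O)(=O)Nc1cccc(NCCNC(=O)c2cccc(Cl)c2)c1` has not yet been measured in this assay. It differs from compound 1 in a single respect, namely (chloro in place of methoxy on an aromatic carbon). Among the measured compounds shown here, no pair of measured compounds shows a step of this kind, so the effect of the exchange cannot be read from the data; all that is known is the single value of compound 1.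

Given the small size of the change and the absence of any measured step, the step from compound 1 to compound 3 is expected to be no change at the digits printed from compound 1 to compound 3 (within the scatter), that is, no shift in either direction that clearly exceeds the usual scatter. Compound 3 is therefore estimated to give 49% in this assay, with a range from 30% to 70%.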

Compound 3, largest response reached (Emax), in percent of the reference or control that the assay uses: 73%
Compound 3: middle estimate off by 24 percentage points, on the low side; measured number outside the range, above it.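

In this assay, among these compounds, the exchange of 3-methoxyphenyl for 3-chlorophenyl gives a number 24 percentage points higher from compound 1 to compound 3 (beyond the scatter) and is the first step in this set that can be read at all. It shows that the largest response is sensitive to the group on this aromatic carbon, meta to a large group: with the rest of the molecule unchanged, putting chloro, a single heavy atom without a hydrogen-bond acceptor, in place of methoxy moves the response upward by more than the scatter. The data shown offer no measured basis for explaining this rise, so it stands here as an observation only.

On these data alone, whether the higher response is particular to chloro or would also appear with another group at this place, such as fluoro, methyl, trifluoromethyl or an amine, remains open, as a single step cannot show a trend across substituents. As far as these compounds go, compound 2 carries no number, so it also remains open how methoxy at another place on this ring would compare, and whether chloro there would raise the response as well.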